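Chloro on the benzyl oxygen arm of compound 2

The source may hold more compounds than are shown below. What is called first, only, known or untested is meant among the compounds shown, and "the series" means these compounds.

Measured compounds:
compound 1 `Cc1ccc(-c2nn(-c3ccccc3)cc2C(=O)NOCc2ccccc2Cl)cc1`: 4680 nM
compound 2 `COc1ccc(-c2nn(-c3ccccc3)cc2C(=O)NOCc2ccccc2)cc1`: 2640 nM

Of the compounds shown here, two have been measured in a functional assay on HeLa cells (Homo sapiens) for antiproliferative activity, read by MTT assay, with a stated time of 48 h, in the presence of a further agent that is not named here; a higher number here means a weaker inhibitor of growth, a lower number a stronger inhibitor of growth. Compound 1 `Cc1ccc(-c2nn(-c3ccccc3)cc2C(=O)NOCc2ccccc2Cl)cc1` gives 4680 nM in this assay. Compound 2 `COc1ccc(-c2nn(-c3ccccc3)cc2C(=O)NOCc2ccccc2)cc1` gives 2640 nM. The number for compound 2 is the lower of the two, but the gap to compound 1 is within the scatter, so neither can be called the stronger inhibitor. Among the measured compounds shown here, the two compounds differ in two places at once, so no single step between measured compounds is at hand.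

Compound 3 `COc1ccc(-c2nn(-c3ccccc3)cc2C(=O)NOCc2ccccc2Cl)cc1` keeps the core of compound 2 and changes one thing: chloro in place of hydrogen on an aromatic carbon. The same change is present in compound 1 relative to compound 2, but there together with a second difference on the other aryl, so its own contribution cannot be read out.

For the measured compounds named here, with no isolated step to lean on, the expectation for compound 3 is a step of a 1.2-fold higher number from compound 2 to compound 3 (0.08 log units; within the scatter) of no size beyond the scatter, in either direction. Compound 3 is therefore estimated at 3200 nM in this assay, with a range from 1200 nM to 8500 nM.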

Compound 3, concentration for 50% growth inhibition: 3480 nM
Compound 3: middle estimate off by 1.1-fold (0.04 log units), on the low side; low and high end bracket the measured number.
By their numbers in this assay, from the lowest: compounds 2, 3 and 1 (each within the scatter of the next).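

The pair of compound 2 and compound 3 isolates chloro in place of hydrogen, which compound 1 could not do, and in this assay the change of benzyl to 2-chlorobenzyl gives a 1.3-fold higher number from compound 2 to compound 3 (0.12 log units; within the scatter). Compound 3 also isolates the other difference carried by compound 1, methoxy in place of methyl on an aromatic carbon, which gives a 1.3-fold lower number from compound 1 to compound 3 (0.13 log units; within the scatter), so that neither single change, taken alone, can be told apart from the scatter in these compounds. No further data at hand bear on this result.

What the compounds shown leave open is whether another group at the chloro position, such as an amine, a carboxylic acid or a longer chain, would give a step beyond the scatter in this assay. As far as these compounds go, they also leave open whether replacing the methoxy with a group such as a nitrile or a hydroxyl would do so, and so the reach of this series beyond these small changes remains unknown.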